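Swapping the aryl group on a shared imidazopyrazine core

The source may report more compounds than this note shows. Statements on the series, on what has been measured and on what is new or still open speak of the compounds shown alone.

Measured compounds:
- compound 1, `c1ccc2c(-c3cn4ccnc4c(-c4ccc5ncn(C6CCCCC6)c5c4)n3)cccc2c1`: 4.46%
- compound 2, `O=Cc1ccc(-c2cn3ccnc3c(-c3ccc4ncn(Cc5ccccc5)c4c3)n2)cc1`: 49.1%

Of the compounds shown here, two have been tested in a functional assay on HCT-15 cells (Homo sapiens) for inhibition, read by sulforhodamine B assay, with a stated time of 48 h, tested at 10 uM; on this read-out lower numbers stand for less inhibition and higher numbers for more inhibition at the one concentration tested (going by the name of the read-out). Compound 1 gives 4.46%. Compound 2 gives 49.1%, the higher of the two numbers, and its gap to compound 1 lies beyond the usual scatter of the method. Within the data shown here, no single-point step between these two compounds is available, since they differ from each other in more than one place.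

Compound 3, `c1ccc(Cn2cnc3ccc(-c4nc(-c5cccc6ccccc56)cn5ccnc45)cc32)cc1`, has not yet been measured in this assay. It differs from compound 2 in one place: naphthalen-1-yl in place of 4-formylphenyl on an aromatic carbon. Compound 1, which also carries naphthalen-1-yl, sits at the low end of what has been seen so far, although it differs from compound 3 elsewhere as well. On that basis compound 3 is expected to come in below compound 2, with the step of a number 29.1 percentage points lower from compound 2 to compound 3 (beyond the scatter) estimated as a drop that goes beyond the scatter. The estimate for compound 3 in this assay is 20%, within a range of 2% to 45%.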

Compound 3, a percentage reported as inhibition, at one concentration (the size of the read-out at that concentration, not a potency): 8.2%
Compound 3: the middle estimate sits 11.8 percentage points above what was measured; the range from low to high includes it.
By their numbers in this assay, from the lowest: compounds 1 and 3 (each within the scatter of the next); then compound 2.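

In this assay, putting naphthalen-1-yl in place of 4-formylphenyl on the aromatic carbon of the six-membered ring with 2 nitrogen gives a number 40.9 percentage points lower from compound 2 to compound 3 (beyond the scatter), the first single change seen to shift the read-out at this position. With naphthalen-1-yl in place, benzyl in place of cyclohexyl on an aromatic nitrogen gives a number 3.7 percentage points higher from compound 1 to compound 3 (within the scatter), so the two groups on that nitrogen cannot be told apart in this assay with this aryl group present. No measurement is available that would explain either result.

The compounds shown leave open which part of 4-formylphenyl goes with the higher number, the formyl group or the phenyl ring itself, a question that a plain phenyl group, a 4-carboxyphenyl group or a 4-aminophenyl group at the same carbon would address. They also leave open whether cyclohexyl and benzyl on the aromatic nitrogen would still stand within the scatter of each other with 4-formylphenyl on the shared core.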